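Methyl Addition on the Five-Membered Ring: Compound 4 Expected

This account rests on a few compounds, and the source may have more. Where it says the series, first, only, none or still open, it means among the compounds named here.

Compound 1, `Cn1ncnc1-c1ccccc1NCC1=NCCN1`: in an in vitro functional assay on cells (Fibroblast) for agonist activity at Alpha-1D adrenergic receptor (Homo sapiens) (on this read-out lower numbers stand for an effect already at smaller amounts and higher numbers for an effect only at larger amounts of compound), compound 1 gives 63.1 nM.
Compound 2, `Cc1nc(-c2ccccc2NCC2=NCCN2)n(C)n1`: in this assay compound 2 reaches only a limit, < 5020 nM.
Compound 3, `Cn1cccc1-c1ccccc1NCC1=NCCN1`: in this assay compound 3 gives 251 nM.

Compound 1 and compound 3 differ only in the ring attached to the shared core: 1-methyl-1H-pyrrol-2-yl in place of 1-methyl-1H-1,2,4-triazol-5-yl on an aromatic carbon. That exchange produces a 4.0-fold higher number from compound 1 to compound 3 (0.60 log units; beyond the scatter).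

Compound 2 is obtained from compound 1 by methyl in place of hydrogen on an aromatic carbon. The step is a step that the limit leaves unreadable from compound 1 to compound 2, because of the limit of < 5020 nM in this assay, at which 1 of the 3 values shown sits.

Compound 4, `Cc1ccc(-c2ccccc2NCC2=NCCN2)n1C`, has not yet been measured. It differs from compound 3 by methyl in place of hydrogen on an aromatic carbon. This is the same kind of change as that from compound 1 to compound 2, but the surroundings differ: in compound 2 the methyl sits between two ring nitrogen atoms of a ring with 3 nitrogen, while in compound 4 it sits next to the ring nitrogen and next to the ring atom that bears a methyl group, in a ring with 1 nitrogen.

Since the earlier step has no readable size, the expectation rests on compound 3 and its value 251 nM with a modest expected penalty, a 2.0-fold higher number from compound 3 to compound 4 (0.30 log units; within the scatter). Compound 4 is thus estimated at 500 nM, with a likely span from 120 nM to 2500 nM.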

Compound 4, half-maximal effective concentration: < 100000 nM
Compound 4: no number, only a limit (the forecaster's own chance of this, stated with the estimate: 15%); the middle value lies beyond the limit too.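

In this assay compound 4 reaches only a limit, < 100000 nM, and the step from compound 3 to compound 4 therefore cannot be read: the limit of < 100000 nM in this assay, at which 1 of the 4 values shown sits.

With compound 2 and compound 4 both giving limits rather than numbers, the compounds shown leave open how large the effect of methyl in place of hydrogen is on either five-membered ring.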